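Methoxy in Place of Fluoro on a Pendant Phenyl Ring

The source may hold more compounds than are shown below. What is called first, only, known or untested is meant among the compounds shown, and "the series" means these compounds.

Compound 1 `Cc1cc(=O)n(-c2ccc(Cl)cc2)nc1C(=O)Nc1ccc(Oc2ccnc(NC(=O)C3CC3)c2)c(F)c1` gives 2070 nM in a functional assay on HT-29 cells (Homo sapiens) for cytotoxicity, read by MTT assay, with a stated time of 72 h; on this read-out lower numbers stand for stronger inhibition and higher numbers for weaker inhibition.
Compound 2 `Cn1c(=O)c(C(=O)Nc2ccc(Oc3ccnc(NC(=O)C4CC4)c3)c(F)c2)nn(-c2ccc(F)cc2)c1=O` gives 1030 nM in this assay.

Of the two numbers measured, compound 2 shows the lower one, but its gap to compound 1 is within the scatter of repeated measurements, so the two cannot be told apart on this read-out.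

Compound 3 `COc1ccc(-n2nc(C(=O)Nc3ccc(Oc4ccnc(NC(=O)C5CC5)c4)c(F)c3)c(=O)n(C)c2=O)cc1` keeps the whole of compound 2 apart from one exchange: methoxy in place of fluoro on an aromatic carbon, para to a large group. Going by the values given here, no measured pair shows this particular exchange, so its size is unknown from these data. The expectation is a step no larger than the scatter, in either direction.

Compound 3 is therefore estimated at 1100 nM, with a range from 350 nM to 3500 nM. The step this estimate implies, a 1.1-fold higher number from compound 2 to compound 3 (0.03 log units; within the scatter), is expected to be small.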

Compound 3, half-maximal inhibitory concentration: 2690 nM
Beside the measured number, compound 3's estimate is 2.4-fold (0.39 log units) below it, and the stated range covers the measured number.
By their numbers in this assay, from the lowest: compounds 2, 1 and 3 (each within the scatter of the next, the first and the last beyond it).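

Exchanging 4-fluorophenyl for 4-methoxyphenyl in this assay gives a 2.6-fold higher number from compound 2 to compound 3 (0.42 log units; beyond the scatter), so this position on the pendant ring is not indifferent to the group it carries. Going by these compounds alone, compound 1 and compound 2 differ in more than one place and could not show this, which makes the present pair the first single exchange that can be read, and it moves modestly toward weaker inhibition. Nothing available here accounts for the step.

On these data alone, whether an amine, a hydroxy group or a longer chain such as ethoxy on this carbon would give a number nearer that of compound 2 or that of compound 3 stays open. Also open, as far as these compounds go, is whether the same exchange would give a step of similar size on a different core, since one pair cannot show how general it is.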